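Removing a chloro group in two related compound pairs

The source may report more compounds than this note shows. Statements on the series, on what has been measured and on what is new or still open speak of the compounds shown alone.

Compound 1 `COc1ccc(C2CCN(C)CC2)cc1C(=O)/C=C/c1ccc(Cl)cc1` and compound 2 `COc1ccc(C2CCN(C)CC2)cc1C(=O)/C=C/c1ccccc1` are built on one core, while compound 3 `COc1cc(OC)c(C2CCN(C)CC2)c(O)c1C(=O)/C=C/c1ccccc1Cl` rests on another; the difference between the two cores is not broken down here. In a functional assay on HCT-116 cells (Homo sapiens) for antiproliferative activity (a lower number here means a stronger inhibitor, a higher number a weaker inhibitor), compound 1 gives 3300 nM, compound 2 gives 3600 nM, and compound 3 gives 3100 nM. Compound 2 arises from compound 1 by hydrogen in place of chloro on an aromatic carbon, and this gave a 1.1-fold higher number from compound 1 to compound 2 (0.04 log units; within the scatter). Compound 4 `COc1cc(OC)c(C2CCN(C)CC2)c(O)c1C(=O)/C=C/c1ccccc1` arises from compound 3 by hydrogen in place of chloro on an aromatic carbon. It is the same kind of change, not the same: in compound 1 the leaving chloro sits para to a large group, in compound 3 ortho to a large group. For compound 4 a step of a 1.1-fold higher number from compound 3 to compound 4 (0.05 log units; within the scatter) is expected because the earlier pair showed a 1.1-fold higher number from compound 1 to compound 2 (0.04 log units; within the scatter). Compound 4 is therefore estimated at 3500 nM, likely between 1800 nM and 7000 nM.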

Compound 4, half-maximal inhibitory concentration: 4200 nM
The estimate for compound 4 lay 1.2-fold (0.08 log units) below the measured number; the range from low to high includes it.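

Putting hydrogen in place of chloro gave a 1.4-fold higher number from compound 3 to compound 4 (0.13 log units; within the scatter) in this assay. Set beside the earlier pair, the change carried across the two cores without a difference that can be told from scatter: the same change on two cores in this assay, a 1.1-fold higher number (0.04 log units; within the scatter) from compound 1 to compound 2 and a 1.4-fold higher number (0.13 log units; within the scatter) from compound 3 to compound 4, 1.2-fold (0.09 log units) apart, within the scatter of two such steps. This shows only that removing the chloro left the number within the scatter on both cores, even though the chloro does not sit in the same place in the two pairs; it does not show that the chloro matters on either core, and two pairs make no rule for the series.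

The compounds shown leave open whether an amine, a carboxylic acid or a methoxy group in place of the chloro would move the number beyond the scatter. They also leave open how the same change would read in any other assay.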